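This account rests on a few compounds, and the source may have more. Where it says the series, first, only, none or still open, it means among the compounds named here.

Compound 1 `COc1cc(OC)cc(N2NC3=CC[C@@H](OC)O[C@@]3(c3ccccc3)CC2=O)c1` and compound 2 `COc1cc(OC)cc(N2NC3=CC[C@@H](OC)O[C@@]3(C)CC2=O)c1` share one core, while compound 3 `CO[C@@H]1CC=C2NN(c3cncnc3)C(=O)C[C@]2(C)O1` and the as yet unmeasured compound 4 `CO[C@@H]1CC=C2NN(c3cncnc3)C(=O)C[C@]2(c2ccccc2)O1` share another; the difference between the two cores is not broken down here. In a functional assay on DU-145 cells (Homo sapiens) for inhibition, read by sulforhodamine B assay, with a stated time of 48 h (a higher number here means a weaker inhibitor, a lower number a stronger inhibitor), compound 2 gives 22200 nM, and compound 1 gives 18300 nM. The change phenyl in place of methyl on a saturated ring carbon thus produced a 1.2-fold lower number from compound 2 to compound 1 (0.08 log units; within the scatter). In this assay compound 3 gives 17100 nM, a number within the scatter of both compound 1 and compound 2. Compound 4 arises from compound 3 by phenyl in place of methyl on a saturated ring carbon. This is the same kind of change as that from compound 2 to compound 1, though its place differs: a ring with 1 oxygen next to the ring oxygen, rather than a ring with 2 nitrogen. Because a 1.2-fold lower number from compound 2 to compound 1 (0.08 log units; within the scatter) stayed within the scatter, the expected step of a 1.1-fold lower number from compound 3 to compound 4 (0.06 log units; within the scatter) is also small. Compound 4 is therefore estimated at 15000 nM, likely between 7000 nM and 32000 nM.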

Compound 4, half-maximal inhibitory concentration: 7330 nM
Estimate against measurement, compound 4: 2.0-fold (0.31 log units) above; the measured number falls inside the stated range.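

In this assay phenyl in place of methyl on a saturated ring carbon gave a 2.3-fold lower number from compound 3 to compound 4 (0.37 log units; beyond the scatter) and so a modest step on this core. Set beside the step on the other core, the two results cannot be told apart: the same change on two cores in this assay, a 1.2-fold lower number (0.08 log units; within the scatter) from compound 2 to compound 1 and a 2.3-fold lower number (0.37 log units; beyond the scatter) from compound 3 to compound 4, 1.9-fold (0.28 log units) apart, within the scatter of two such steps. The change can therefore be carried between these two cores with a size consistent with one shared step, but with a single pair on each core this does not show that the two cores respond alike.

The compounds shown leave open what other groups on that saturated ring carbon, such as an amine, a carboxylic acid or a longer chain, would do in this assay. On these data alone, whether the step from methyl to phenyl holds on any further core also remains open.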